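Antiproliferative series: spiro cores with triazolylmethyl amides

This account rests on a few compounds, and the source may have more. Where it says the series, first, only, none or still open, it means among the compounds named here.

The series shares one core, varied at the aryl group on the triazole nitrogen and at one position on the fused aromatic part. Compound 1 has the structure `N#CC1=C(N)Oc2c(c3nc4ccccc4nc3c3ccccc23)C12C(=O)N(Cc1cnnn1-c1ccc([N+](=O)[O-])cc1)c1ccccc12`. In an ADME assay on HUVEC cells (Homo sapiens) for antiproliferative activity, read by MTT assay, with a stated time of 48 h (a higher number here means a weaker inhibitor, a lower number a stronger inhibitor), compound 1 gives only a limit, > 50000 nM. Compound 2 has the structure `N#CC1=C(N)Oc2c(c3nc4ccccc4nc3c3ccccc23)C12C(=O)N(Cc1cnnn1-c1cc(Cl)ccc1Cl)c1ccccc12`. In this assay compound 2 likewise gives only a limit, > 50000 nM. The step that the two limits leave unreadable from compound 1 to compound 2 is therefore unreadable. Compound 3 carries an amino group on the fused aromatic part and has the structure `N#CC1=C(N)Oc2c(N)cc3nc4ccccc4nc3c2C12C(=O)N(Cc1cnnn1-c1cccc(C(F)(F)F)c1)c1ccccc12`. In this assay compound 3 also stands at a limit, > 50000 nM. Going by the values given here, all three measured values sit together at the limit of > 50000 nM in this assay, at which 3 of the 3 values shown sit, so no measured step has a readable size.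

Compound 4, structure `N#CC1=C(N)Oc2c(N)cc3nc4ccccc4nc3c2C12C(=O)N(Cc1cnnn1-c1ccc(F)c(Cl)c1)c1ccccc12`, differs from compound 3 by 3-chloro-4-fluorophenyl in place of 3-(trifluoromethyl)phenyl on an aromatic nitrogen. Among the compounds with values here, the only comparable step, the exchange of one aryl group on the triazole nitrogen from compound 1 to compound 2, is unreadable, and nothing measured points to a move away from the limit. The step from compound 3 to compound 4 is therefore expected to be a step that the limit leaves unreadable from compound 3 to compound 4, that is, nothing beyond the scatter. In this assay compound 4 is estimated at 60000 nM, within 20000 nM to 200000 nM, most likely again reported only as a limit.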

Compound 4, half-maximal inhibitory concentration: > 50000 nM
Compound 4: a limit, no number (the forecaster's own chance of this, stated with the estimate: 85%); the middle value lies beyond the limit too.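

In this assay compound 4 gives > 50000 nM, a limit and not a number. The step from compound 3 to compound 4 thus cannot be read, and the series stays at one limit: the limit of > 50000 nM in this assay, at which 4 of the 4 values shown sit.

The compounds shown leave open whether any aryl group on the triazole nitrogen, or the amino group on the fused aromatic part, affects antiproliferative activity in this assay.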